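From an unsubstituted ring nitrogen to an isopentyl chain

The source may report more compounds than this note shows. Statements on the series, on what has been measured and on what is new or still open speak of the compounds shown alone.

Compound 1, `CN1CCN(c2nc3ccccc3n2CCOc2ccccc2)CC1`, gives 6.9 nM in a functional assay on ileum for inhibition of histamine H1 receptor (Cavia porcellus); a higher number here means a weaker inhibitor, a lower number a stronger inhibitor.
Compound 2, `CCSCCCn1c(N2CCN(C)CC2)nc2ccccc21`, gives 530 nM in this assay.
Compound 3, `CN1CCN(c2nc3ccccc3[nH]2)CC1`, shows only a limit in this assay: > 3000 nM.

Compound 3 stands at the weak end of the measured set; its result is a limit rather than a number, (the limit of > 3000 nM in this assay, at which 1 of the 3 values shown sits). The two measured steps are large: a 77-fold higher number from compound 1 to compound 2 (1.89 log units; beyond the scatter), and an at least 5.6-fold higher number from compound 2 to compound 3 (0.75 log units; beyond the scatter). Compound 4, `CC(C)CCn1c(N2CCN(C)CC2)nc2ccccc21`, differs from compound 3 by isopentyl in place of hydrogen on an aromatic nitrogen.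

The step from compound 2 to compound 3 bears directly on this change, since it removed a chain from the same ring nitrogen and the number rose by at least a modest amount. Compound 4 puts a chain of similar length back on that nitrogen, though without the sulfur of compound 2, so the reverse direction is expected: a lower number, of a size comparable to that step. The step from compound 1 to compound 2 suggests the chain's end group matters greatly, so a plain alkyl chain is not expected to reach compound 1. Compound 4 is therefore estimated at 900 nM, between 250 nM and 3000 nM, meaning an at least 3.3-fold lower number from compound 3 to compound 4 (0.52 log units; beyond the scatter).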

Compound 4, half-maximal inhibitory concentration: 1400 nM
For compound 4 the middle estimate is 1.6-fold (0.19 log units) below the measured one, within the range that was stated.
By their numbers in this assay, from the lowest: compound 1; then compound 2; then compound 4. At a limit, above all of these: compound 3.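

Placing isopentyl on the aromatic nitrogen in this assay gives an at least 2.1-fold lower number from compound 3 to compound 4 (0.33 log units; beyond the scatter), so a chain made only of carbon is enough to move the number, with no sulfur or oxygen present. The true size of that step remains unknown because the value for compound 3 is only a limit: the limit of > 3000 nM in this assay, at which 1 of the 4 values shown sits. Changing the end of the chain has very unequal results: the sulfur-containing chain and isopentyl are separated by a 2.6-fold higher number from compound 2 to compound 4 (0.42 log units; beyond the scatter), whereas the phenoxy-ended chain and isopentyl are separated by a 200-fold higher number from compound 1 to compound 4 (2.31 log units; beyond the scatter), so among these three chains the phenoxy-ended one stands far apart.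

The compounds shown leave open whether the advantage of compound 1 comes from the aromatic ring of the phenoxy group or from its ether oxygen, a question that a chain ending in plain phenyl would help to separate. They also leave open how a longer straight alkyl chain, or a chain ending in an amine or a carboxylic acid, would compare with compound 4 and compound 1.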